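The source may report more compounds than this note shows. Statements on the series, on what has been measured and on what is new or still open speak of the compounds shown alone.

Measured so far in an assay on microsomes from brain for inhibition of Fatty-acid amide hydrolase 1 (Rattus norvegicus), read by fluorescence and HPLC, with a stated time of 60 min; on this read-out higher numbers stand for weaker inhibition and lower numbers for stronger inhibition:
- compound 1 `CCCCCCCCc1ccc(OCC(=O)Cn2nnc3cccnc32)cc1`: 13 nM
- compound 2 `CCCCCCCCc1ccc(OCC(=O)Cn2cnnn2)cc1`: 39 nM

Among the measured compounds shown here, compound 2 holds the highest of the two numbers in this assay; its only neighbour is compound 1, and the step of a 3.0-fold higher number from compound 1 to compound 2 (0.48 log units; beyond the scatter) is a modest rise that exchanges one ring group for another of different size.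

Compound 3 `CCCCCCCCc1ccc(OCC(=O)Cn2ncnn2)cc1` is not yet measured. It differs from compound 2 by 2H-tetrazol-2-yl in place of 1H-tetrazol-1-yl on a saturated chain carbon bound to a carbonyl carbon. For the measured compounds named here, no measured step touches this kind of change: the single step from compound 1 to compound 2 replaces the whole group rather than rearranging the same atoms within it, so it gives no direct guide here. The expectation for this assay is therefore a step of no size beyond the scatter, in either direction, expressed as a 1.0-fold higher number from compound 2 to compound 3 (0.01 log units; within the scatter). Compound 3 is estimated at 40 nM, with a range from 13 nM to 120 nM to reflect the absence of a bearing step.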

Compound 3, half-maximal inhibitory concentration: 10 nM
Beside the measured number, compound 3's estimate is 4.0-fold (0.60 log units) above it; the whole stated range lies above it.
By their numbers in this assay, from the lowest: compounds 3 and 1 (each within the scatter of the next); then compound 2.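

In this assay, the way the tetrazole is joined at this place, on a saturated chain carbon bound to a carbonyl carbon, counts on its own: with the same atoms, 2H-tetrazol-2-yl in place of 1H-tetrazol-1-yl gives a 3.9-fold lower number from compound 2 to compound 3 (0.59 log units; beyond the scatter). Size of the group therefore does not decide the result at this position, since the smaller 2H-tetrazol-2-yl group gives a 1.3-fold lower number from compound 1 to compound 3 (0.11 log units; within the scatter) against the larger group of compound 1, a step within the scatter. No measurement here accounts for the difference between the two tetrazoles.

As far as these compounds go, whether a 1,2,3-triazol-2-yl or pyrazol-1-yl group at this place would show a similar dependence on how the ring is joined remains open. Also open, from the compounds shown here alone, is whether the step between the two tetrazoles persists with a shorter chain than octyl.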